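The compounds below may be only part of what the source reports. "The series", "measured", "known", "first", "only" and "open" are said of these compounds alone.

Two measured compounds share one core and differ only in the group on the phenyl ring of the benzyl arm. Compound 1 `Cc1cc(C)c(NC(=O)N(Cc2ccc(N3CCN(C)CC3)cc2)C2CCCCCC2)c(C)c1` gives in an assay on microsomes from intestine for inhibition of acyl-CoA:cholesterol acyltransferase (Oryctolagus cuniculus) (on this read-out higher numbers stand for weaker inhibition and lower numbers for stronger inhibition), 57 nM. For the measured compounds named here, compound 2 `Cc1cc(C)c(NC(=O)N(Cc2ccc(-c3cn[nH]c3)cc2)C2CCCCCC2)c(C)c1` gives in this assay 270 nM, the highest of the two numbers so far; the step of a 4.7-fold higher number from compound 1 to compound 2 (0.68 log units; beyond the scatter) lies beyond the scatter.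

Compound 3 `Cc1cc(C)c(NC(=O)N(Cc2ccc(-n3ccnc3)cc2)C2CCCCCC2)c(C)c1` has not yet been measured. It differs from compound 2 by 1H-imidazol-1-yl in place of 1H-pyrazol-4-yl on an aromatic carbon. Going by the values given here, no measured step bears directly on this change: the only step in hand, a 4.7-fold higher number from compound 1 to compound 2 (0.68 log units; beyond the scatter), concerns the exchange of 4-methylpiperazin-1-yl for 1H-pyrazol-4-yl, a different kind of change from the rearrangement of one five-membered ring with two nitrogens into another. Among the compounds with values here, it shows only that the group at this place can move the number in this assay by a modest amount. With no closer comparison available, the expected step of a 1.1-fold higher number from compound 2 to compound 3 (0.05 log units; within the scatter) is taken as small, in either direction, and not clearly beyond the scatter. For compound 3 the estimate in this assay is 300 nM, with a range from 100 nM to 900 nM.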

Compound 3, half-maximal inhibitory concentration: 47 nM
Estimate against measurement, compound 3: 6.4-fold (0.81 log units) above; measured number outside the range, below it.
By their numbers in this assay, from the lowest: compounds 3 and 1 (each within the scatter of the next); then compound 2.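

In this assay, the swap of 1H-pyrazol-4-yl for 1H-imidazol-1-yl gives a 5.7-fold lower number from compound 2 to compound 3 (0.76 log units; beyond the scatter), so at this place, on an aromatic carbon para to a large group, two rings with the same heavy atoms are not interchangeable: how the ring is joined and where its nitrogens lie can shift the number beyond the scatter. The other new step, a 1.2-fold lower number from compound 1 to compound 3 (0.08 log units; within the scatter), lies within the scatter, so 1H-imidazol-1-yl and 4-methylpiperazin-1-yl cannot be told apart here despite being very different groups, and compound 2 alone stands apart among the three. The counted difference between the two five-membered rings is 1 hydrogen-bond donor and 1 acceptor against 0 donors and 2 acceptors, but nothing at hand links that difference or any other to the shift in the number.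

Still open, as far as these compounds go, is whether the hydrogen on the ring nitrogen of compound 2 matters, which a 1-methyl-1H-pyrazol-4-yl group would test. Also open, from the compounds shown here alone, is how a 1H-pyrazol-1-yl, a 1H-1,2,4-triazol-1-yl or a plain phenyl ring would compare at this place on the shared core.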